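A few compounds are considered here, and "the series" means these few. Any claim that something is new, unique, unknown or untested is made for them only; others in the source may bear on it.

Measured so far in the series:

compound 1 `O=c1[nH]c2ccc(Cl)cc2n1S(=O)(=O)c1cccc(F)c1`: 128000 nM
compound 2 `O=C1CN(S(=O)(=O)c2cccc(F)c2)c2cc(Cl)ccc2N1`: 189000 nM
compound 3 `N#Cc1cccc(S(=O)(=O)n2c(=O)[nH]c3ccc(Cl)cc32)c1`: 205000 nM

All three were run in an ADME assay on MT4 cells (Homo sapiens) for cytotoxicity, with a stated time of 5 days; a lower number here means that less compound is tolerated, a higher number that more compound is tolerated. Compound 1 and compound 3 share one core, and compound 3 carries the change (cyano in place of fluoro on an aromatic carbon). That step gave a 1.6-fold higher number from compound 1 to compound 3 (0.20 log units; within the scatter). Compound 2 has a different core from compound 1; the difference between the two cores is not broken down here. In this assay compound 2 stands close to compound 3, and its gap to compound 1 is also within the scatter, so no order among the three is claimed.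

Compound 4 `N#Cc1cccc(S(=O)(=O)N2CC(=O)Nc3ccc(Cl)cc32)c1` is not yet measured. It is related to compound 2 by the same change as that from compound 1 to compound 3, namely (cyano in place of fluoro on an aromatic carbon); the place of the change is described in the same words for both pairs, so it is taken as the same change on the core of compound 2. On that basis, and on the size of a 1.6-fold higher number from compound 1 to compound 3 (0.20 log units; within the scatter), the step from compound 2 to compound 4 is expected to be a 1.4-fold higher number from compound 2 to compound 4 (0.14 log units; within the scatter), which stays within the scatter. The expected value for compound 4 in this assay is 260000 nM, estimated to lie between 150000 nM and 450000 nM.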

Compound 4, half-maximal cytotoxic concentration: 186000 nM
For compound 4 the middle estimate is 1.4-fold (0.15 log units) above the measured one; measured number inside the range.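

In this assay, cyano in place of fluoro on the second core gives a 1.0-fold lower number from compound 2 to compound 4 (0.01 log units; within the scatter), so on this core the change shows no step larger than the scatter. Set beside the same change on the first core, the new step does not differ from the earlier one: the same change on two cores in this assay, a 1.6-fold higher number (0.20 log units; within the scatter) from compound 1 to compound 3 and a 1.0-fold lower number (0.01 log units; within the scatter) from compound 2 to compound 4, 1.6-fold (0.21 log units) apart, within the scatter of two such steps. This shows that, for these two pairs, the change stays within the scatter on both cores, and that the choice of core gives no measurable difference in its outcome; it does not show that the change has no effect in general, nor that the same would hold on a further core or at another place on the ring.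

The compounds shown leave open what an amine, a carboxylic acid or a longer chain at this place would give on either core in this assay. They also leave open what replacing the chloro group, present in all four compounds, would do to the number.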